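The source may hold more compounds than are shown below. What is called first, only, known or untested is meant among the compounds shown, and "the series" means these compounds.

Measured in a functional assay on A549 cells (Homo sapiens) for cytotoxicity, read by MTT assay, with a stated time of 72 h; on this read-out higher numbers stand for weaker inhibition and lower numbers for stronger inhibition:
compound 1 `O=C(Nc1ccc(Oc2ccnc3[nH]ccc23)cc1)c1nccc(-c2ccc(Cl)cc2)n1` gives 22400 nM
compound 2 `COc1ccc(-c2cc(C(=O)Nc3ccc(Oc4ccnc5[nH]ccc45)cc3)ncn2)cc1` gives 4410 nM
compound 3 `O=C(Nc1ccc(Oc2ccnc3[nH]ccc23)cc1)c1cc(-c2ccc(F)cc2)ncn1` gives 13000 nM

Compound 3 holds the second highest of the three numbers in this assay. Its gap to compound 1 lies within the usual scatter, so no order can be drawn between these two, while compound 2 sits clearly lower. Among the compounds with values here, only one single-point step links the measured set: a 2.9-fold higher number from compound 2 to compound 3 (0.47 log units; beyond the scatter), a modest step beyond the scatter.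

Compound 4 `O=C(Nc1ccc(Oc2ccnc3[nH]ccc23)cc1)c1cc(-c2ccc(Cl)cc2)ncn1` differs from compound 3 in one place: chloro in place of fluoro on an aromatic carbon. Within the data shown here, no measured step tests this exchange directly. Among the measured compounds shown here, the one recorded step, a 2.9-fold higher number from compound 2 to compound 3 (0.47 log units; beyond the scatter), concerns methoxy against fluoro and says nothing about chloro. Compound 1 carries a 4-chlorophenyl group on a different core, and its number and that of compound 3 stand within the scatter of each other, which offers no ground for expecting a shift in either direction. For compound 4 the expected step is therefore no change at the digits printed from compound 3 to compound 4 (within the scatter), nothing beyond the scatter. Compound 4 is accordingly estimated at 13000 nM, with a range from 5000 nM to 35000 nM.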

Compound 4, half-maximal inhibitory concentration: 6530 nM
Estimate against measurement, compound 4: 2.0-fold (0.30 log units) above; the range from low to high includes it.
By their numbers in this assay, from the lowest: compounds 2, 4, 3 and 1 (each within the scatter of the next, the first and the last beyond it).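

In this assay, the exchange of 4-fluorophenyl for 4-chlorophenyl gives a 2.0-fold lower number from compound 3 to compound 4 (0.30 log units; within the scatter), so on this aromatic carbon, para to a large group, the two halogens cannot be told apart. Chloro also cannot be told apart from methoxy at this place, as a 1.5-fold higher number from compound 2 to compound 4 (0.17 log units; within the scatter) shows, although the earlier step of a 2.9-fold higher number from compound 2 to compound 3 (0.47 log units; beyond the scatter) separates fluoro from methoxy. The three groups therefore fall into no clean order: chloro stands within the scatter of both, and only the methoxy and fluoro pair is resolved, while no evidence at hand speaks to the reason for these numbers.

The compounds shown leave open whether a different kind of group at this place, such as an amine, a carboxylic acid or a trifluoromethyl, would give a number beyond the scatter of these three. They also leave open whether the exchange of fluoro for chloro would read the same way on the core of compound 1, where only the chloro group is shown.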